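Adding a second methoxy to compound 2

The compounds below may be only part of what the source reports. "The series", "measured", "known", "first", "only" and "open" are said of these compounds alone.

Values so far in a functional assay on HeLa cells (Homo sapiens) for antiproliferative activity, read by cell counting, with a stated time of 3 days; a lower number here means a stronger inhibitor, a higher number a weaker inhibitor
compound 1 `CC(Nc1ccccc1Oc1cccc(F)c1)=C1C(=O)CC(c2ccccc2)CC1=O` with 550 nM
compound 2 `COc1ccc(Oc2ccccc2NC(C)=C2C(=O)CC(c3ccccc3)CC2=O)cc1` with 160 nM

Compound 2 at 160 nM holds the lower of the two numbers, and its gap to compound 1 lies beyond the scatter. Among the compounds with values here, the only measured step is a 3.4-fold lower number from compound 1 to compound 2 (0.54 log units; beyond the scatter) and it brings 4-methoxyphenyl in place of 3-fluorophenyl on an oxygen on an aromatic ring.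

The next compound is compound 3 `COc1ccc(Oc2ccccc2NC(C)=C2C(=O)CC(c3ccccc3)CC2=O)cc1OC` which turns 4-methoxyphenyl into 3,4-dimethoxyphenyl. The change is methoxy in place of hydrogen on an aromatic carbon with methoxy in place of hydrogen on an aromatic carbon, ortho to a methoxy group and meta to a large group.

Within the data shown here, the one measured step is modest and exchanges one substituted ring for another, so it does not test a methoxy added to a ring that already carries one. It offers no direction for this change, and no step beyond the scatter is expected in this assay for now. The expected change is a 1.1-fold lower number from compound 2 to compound 3 (0.03 log units; within the scatter) and it rests on this single comparison. In this assay the estimate for compound 3 is 150 nM with an expected range from 50 nM to 450 nM for this measurement.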

Compound 3, half-maximal inhibitory concentration: 54 nM
Estimate against measurement, compound 3: 2.8-fold (0.44 log units) above, within the range that was stated.
By their numbers in this assay, from the lowest: compound 3; then compound 2; then compound 1.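

In this assay, a methoxy placed ortho to a methoxy group and meta to a large group gives a 3.0-fold lower number from compound 2 to compound 3 (0.47 log units; beyond the scatter), so this ring position accepts a second methoxy and the number falls by more than the scatter, which the earlier exchange of one substituted ring for another could not show. Across the full exchange of 3-fluorophenyl for 3,4-dimethoxyphenyl on the oxygen, the series shows a 10-fold lower number from compound 1 to compound 3 (1.01 log units; beyond the scatter), which places compound 3 lowest of the three, with its steps to both other compounds beyond the scatter, and shows that substitution on this ring alone can move the number by a large step. Nothing available accounts for either step, and the reason for the gain stays unknown.

The compounds shown leave open whether the methoxy itself matters at this position or whether a hydroxy, an amine or a longer ether such as ethoxy would give a similar number. They also leave open whether the new methoxy gives the same step on its own, as a 3-methoxyphenyl ring with no methoxy at the 4-position.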